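The compounds below may be only part of what the source reports. "The series", "measured", "known", "first", "only" and "open" are said of these compounds alone.

Measured so far in an in vivo ADME assay on the whole organism (strain Mongrel) for pharmacokinetics, with Canis familiaris (Canis lupus familiaris) as the target; a higher number here means faster removal of the compound, a lower number slower removal:
- Compound 1, `COc1cncc(C(=O)NC2(C(=O)N[C@H](C)c3ccc(-n4nc(Cl)c5ccccc54)cc3F)CC2)c1`: in this assay compound 1 gives 5.5 mL/min/kg.
- Compound 2, `C[C@@H](NC(=O)C1(NC(=O)c2cncs2)CC1)c1ccc(-n2nc(Cl)c3ccccc32)cc1F`: in this assay compound 2 gives 1.1 mL/min/kg.

Compound 2 stands at the lower of the two numbers; its nearest neighbour is compound 1, and the change from one to the other is a 5.0-fold lower number from compound 1 to compound 2 (0.70 log units; beyond the scatter), a step that swaps the aryl group on the carbonyl carbon and is beyond the scatter.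

Compound 3, `Cc1nnsc1C(=O)NC1(C(=O)N[C@H](C)c2ccc(-n3nc(Cl)c4ccccc43)cc2F)CC1`, has not yet been measured in this assay. It differs from compound 2 in one place: 4-methyl-1,2,3-thiadiazol-5-yl in place of 1,3-thiazol-5-yl on a carbonyl carbon.

Within the data shown here, no measured step covers this particular exchange. Among the measured compounds shown here, the only step that bears on it, a 5.0-fold lower number from compound 1 to compound 2 (0.70 log units; beyond the scatter), shows that changing the group on this carbonyl carbon can move the clearance by a modest amount. Since the group entering in compound 3 is again a small five-membered heteroaryl rather than the six-membered one of compound 1, the step is expected to be small, with little room to fall further given that compound 2 already sits at the lowest number. Compound 3 is therefore expected to show a 1.5-fold higher number from compound 2 to compound 3 (0.16 log units; within the scatter), a slight rise at most. The estimate for compound 3 is 1.6 mL/min/kg, with a range from 0.6 mL/min/kg to 4.5 mL/min/kg.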

Compound 3, clearance: 9.6 mL/min/kg
Compound 3: middle estimate off by 6.0-fold (0.78 log units), on the low side; the measured number lies above the stated range.
By their numbers in this assay, from the lowest: compound 2; then compounds 1 and 3 (each within the scatter of the next).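

The step of an 8.7-fold higher number from compound 2 to compound 3 (0.94 log units; beyond the scatter) in this assay shows that ring size alone does not settle the number at this position: both groups are five-membered aromatic rings on the same carbonyl carbon, yet the step lies beyond the scatter. With the step of a 1.7-fold higher number from compound 1 to compound 3 (0.24 log units; within the scatter), the 4-methyl-1,2,3-thiadiazol-5-yl group does not separate from the six-membered 5-methoxypyridin-3-yl group, so of the three groups shown, only the 1,3-thiazol-5-yl group gives a number set apart from the others. Nothing among the data shown accounts for this difference.

The exchange alters two things at once, the methyl group and the set of ring hetero atoms, and the three compounds cannot tell which of these goes with the higher number. As far as these compounds go, a 4-methyl-1,3-thiazol-5-yl group or a 1,2,3-thiadiazol-5-yl group without the methyl would separate the two, and it remains open whether the low number of compound 2 is particular to the 1,3-thiazol-5-yl group or is shared by other five-membered rings, such as an oxazole or an isothiazole.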